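The source may hold more compounds than are shown below. What is called first, only, known or untested is meant among the compounds shown, and "the series" means these compounds.

Measured so far in a functional assay on KG-1 cells (Homo sapiens) for antiproliferative activity; on this read-out higher numbers stand for an effect only at larger amounts of compound and lower numbers for an effect already at smaller amounts:
compound 1, `CC1(C#Cc2c(Cl)c3c(Cl)cc(C(N)=O)nc3n2[C@H]2CCCNC2)COC1`: 119 nM
compound 2, `CC(O)C#Cc1c(Cl)c2c(Cl)cc(C(N)=O)nc2n1[C@H]1CCCNC1`: 147 nM
compound 3, `NC(=O)c1cc(Cl)c2c(Cl)c(C#CC3CCCO3)n([C@H]3CCCNC3)c2n1`: 223 nM; 91 nM (2 entries)

Compound 2 and compound 1 carry the two single numbers of the set; the step of a 1.2-fold higher number from compound 1 to compound 2 (0.09 log units; within the scatter) leaves them within the scatter of each other, so no order between them can be read. Compound 3 gives no single number, as the several entries of compound 3 in this assay, 223 nM; 91 nM (2 entries) shows two entries rather than one.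

Compound 4, `CC(C)(CC#Cc1c(Cl)c2c(Cl)cc(C(N)=O)nc2n1[C@H]1CCCNC1)C(N)=O`, has not been measured. It differs from compound 2 only at the triple-bonded carbon: 2-carbamoyl-2-methylpropyl in place of 1-hydroxyethyl on a triple-bonded carbon. Among the measured compounds shown here, the one measured step that speaks to this position is the exchange from compound 1 to compound 2, a 1.2-fold higher number from compound 1 to compound 2 (0.09 log units; within the scatter), a within-scatter change for a swap of a ring-bearing group against 1-hydroxyethyl on the same triple-bonded carbon. For the measured compounds named here, the 2-carbamoyl-2-methylpropyl group is larger than either of those, yet no measured step in the set addresses a group of that kind at this position, so the precedent is a single small step. For compound 4 a step of a 1.0-fold higher number from compound 2 to compound 4 (0.01 log units; within the scatter) is therefore expected, that is, no change beyond the scatter. Compound 4 is estimated in this assay at 150 nM, with a range from 60 nM to 400 nM.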

Compound 4, half-maximal effective concentration: 269 nM
Compound 4: the middle estimate sits 1.8-fold (0.25 log units) below what was measured; measured number inside the range.
By their numbers in this assay, from the lowest: compounds 1, 2 and 4 (each within the scatter of the next, the first and the last beyond it).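

On the triple-bonded carbon, exchanging 1-hydroxyethyl with its 3 heavy atoms for the open chain 2-carbamoyl-2-methylpropyl with its 7 heavy atoms gives in this assay a 1.8-fold higher number from compound 2 to compound 4 (0.26 log units; within the scatter) and so shows that this position can carry a clearly larger group ending in a carbamoyl without a step beyond the scatter from compound 2. Among the compounds shown here, the same group set against 3-methyloxetan-3-yl gives a 2.3-fold higher number from compound 1 to compound 4 (0.35 log units; beyond the scatter) and this is the first step at this position to pass the scatter, though it is modest and joins only the two ends of a row in which each neighbouring pair stays within the scatter. Compound 3 cannot be placed in that row, as it has no single number: the several entries of compound 3 in this assay, 223 nM; 91 nM (2 entries)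

Still open, from the compounds shown here alone, is whether the step from compound 1 comes from the length of the chain or from its carbamoyl end, which a plain 2,2-dimethylpropyl chain on the same carbon would help to separate. Also open, going by these compounds, is how a primary amine, a carboxylic acid or a longer chain ending in a carbamoyl would read at this position.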